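The source may report more compounds than this note shows. Statements on the series, on what has been measured and on what is new or still open speak of the compounds shown alone.

Compound 1 `CCCn1nc(-c2cccnc2)c2ccccc2c1=O` gives 3160 nM in a functional assay (trachea) with Cavia porcellus as the target; on this read-out lower numbers stand for stronger inhibition and higher numbers for weaker inhibition; compound 2 `O=c1c2ccccc2c(-c2cccnc2)nn1C1CCCC1` gives 2750 nM in this assay, so the two numbers stand within the scatter of each other. Among the compounds with values here, the only known step, a 1.1-fold lower number from compound 1 to compound 2 (0.06 log units; within the scatter), swaps the group on the aromatic nitrogen and offers no guide to a long extension of that chain. Compound 3 `O=c1c2ccccc2c(-c2cccnc2)nn1CCCCSc1ncccn1` differs from compound 1 by ((pyrimidin-2-yl)sulfanyl)methyl in place of hydrogen on a saturated chain carbon, three bonds along the chain from an aromatic nitrogen. Within the data shown here, with no measured step of this kind, no shift beyond the scatter is expected, though the range is kept wide. Compound 3 is estimated at 2500 nM, between 700 nM and 9000 nM, which amounts to an expected 1.3-fold lower number from compound 1 to compound 3 (0.10 log units; within the scatter).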

Compound 3, half-maximal inhibitory concentration: 6170 nM
Compound 3: the middle estimate sits 2.5-fold (0.39 log units) below what was measured; the measured number falls inside the stated range.
By their numbers in this assay, from the lowest: compounds 2, 1 and 3 (each within the scatter of the next, the first and the last beyond it).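

On the saturated chain carbon, three bonds along the chain from an aromatic nitrogen, ((pyrimidin-2-yl)sulfanyl)methyl in place of hydrogen gives a 2.0-fold higher number from compound 1 to compound 3 (0.29 log units; within the scatter) in this assay. A group of 8 heavy atoms with one six-membered aromatic ring is thus tolerated at this position without a shift beyond the scatter, which the earlier swap on the aromatic nitrogen could not show. No supporting data explain this result. From the compounds shown here alone, whether an amine or a carboxylic acid at the chain end, or a longer chain, would move the number beyond the scatter stays open.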